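Aryl variation on the ring nitrogen of a bromopyrimidine series

The source may hold more compounds than are shown below. What is called first, only, known or untested is meant among the compounds shown, and "the series" means these compounds.

Of the compounds shown here, two have been measured in a functional assay on U-937 cells (Homo sapiens) for antiproliferative activity, read by MTT assay, with a stated time of 24 h; on this read-out higher numbers stand for weaker inhibition and lower numbers for stronger inhibition. Compound 1 `CNC(=O)c1ccccc1Oc1nc(Nc2ccccc2OC)ncc1Br` gives 52100 nM in this assay. Compound 2 `CNC(=O)c1ccccc1Oc1nc(Nc2ccc(C)cc2C)ncc1Br` gives 49600 nM in this assay. The step of a 1.1-fold lower number from compound 1 to compound 2 (0.02 log units; within the scatter) is the only one measured so far, and it lies within the scatter. On the numbers shown, compound 2 has the lowest of the two values, but its nearest neighbour is compound 1 and the gap between them is within the scatter, so no order between them can be claimed.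

Compound 3 `CNC(=O)c1ccccc1Oc1nc(Nc2cccc(C(C)C)c2)ncc1Br` is not yet measured. It differs from compound 2 by 3-isopropylphenyl in place of 2,4-dimethylphenyl on a nitrogen on an aromatic ring. Going by the values given here, the one measured step that bears on this change is the aryl swap from compound 1 to compound 2, which changed the number in this assay by an amount within the scatter. Another aryl swap at the same nitrogen is therefore expected to give a step of a 1.0-fold higher number from compound 2 to compound 3 (0.00 log units; within the scatter), with no change beyond the scatter in either direction. Compound 3 is estimated at 50000 nM in this assay, within a range from 20000 nM to 125000 nM.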

Compound 3, half-maximal inhibitory concentration: 14100 nM
For compound 3 the middle estimate is 3.5-fold (0.55 log units) above the measured one; the measured number lies below the stated range.
By their numbers in this assay, from the lowest: compound 3; then compounds 2 and 1 (each within the scatter of the next).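

In this assay the aryl group on the nitrogen turns out not to be silent: 3-isopropylphenyl in place of 2,4-dimethylphenyl gives a 3.5-fold lower number from compound 2 to compound 3 (0.55 log units; beyond the scatter), and 3-isopropylphenyl in place of 2-methoxyphenyl gives a 3.7-fold lower number from compound 1 to compound 3 (0.57 log units; beyond the scatter). Going by these compounds alone, the earlier swap at this nitrogen stayed within the scatter, so these modest steps are the first sign that this place can move the number at all. The two steps agree. Compounds 1 and 2 cannot be told apart. The change from compound 2 to compound 3 exchanges one hydrocarbon-substituted phenyl group for another, 8 heavy atoms for 9 with no hydrogen-bond donors or acceptors on either side, and nothing available speaks to why the number moves.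

This step alters both the kind of substituent and its place on the ring, so the shown compounds cannot say which of the two matters. A 3-methylphenyl or a 4-isopropylphenyl group would begin to separate them, while a 3-morpholinophenyl or a 3-carboxyphenyl group would show whether the trend extends beyond hydrocarbon substituents.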